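Pentyloxy to phenethyloxy on the shared core

The compounds below may be only part of what the source reports. "The series", "measured", "known", "first", "only" and "open" are said of these compounds alone.

Compound 1 `CCc1sc(CCc2cc(OC)cc(NCc3cc(Cl)cc(NC(=O)OC(C)C)c3)n2)nc1C` carries a methoxy group on the shared core and in an assay on cells for binding affinity to Neuropeptide Y receptor type 1 (Homo sapiens) (on this read-out higher numbers stand for weaker inhibition and lower numbers for stronger inhibition), compound 1 gives 234 nM. Compound 2 `CCCCCOc1cc(CCc2nc(C)c(CC)s2)nc(NCc2cc(Cl)cc(NC(=O)OC(C)C)c2)c1` differs only in the ether chain, and in this assay compound 2 gives 35 nM. Among the measured compounds shown here, the single step between them, a 6.7-fold lower number from compound 1 to compound 2 (0.83 log units; beyond the scatter), is the only one measured. Among the two numbers shown, compound 2 holds the lowest, with compound 1 its nearest neighbour.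

Compound 3 `CCc1sc(CCc2cc(OCCc3ccccc3)cc(NCc3cc(Cl)cc(NC(=O)OC(C)C)c3)n2)nc1C` carries the change (phenyl in place of propyl on a saturated chain carbon, two bonds along the chain from an oxygen on an aromatic ring). For the measured compounds named here, only the step from compound 1 to compound 2 bears on this, and it concerns the length of the same chain rather than the group at its end, so it gives a direction but not a size. With the chain kept at a comparable length, no step beyond the scatter is expected in this assay for compound 3, which is estimated as a 1.1-fold higher number from compound 2 to compound 3 (0.06 log units; within the scatter). Compound 3 is therefore expected to give about 40 nM, in a range from 12 nM to 130 nM.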

Compound 3, half-maximal inhibitory concentration: 30 nM
For compound 3 the middle estimate is 1.3-fold (0.12 log units) above the measured one; measured number inside the range.
By their numbers in this assay, from the lowest: compounds 3 and 2 (each within the scatter of the next); then compound 1.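

In this assay, the exchange of the open chain end for a ring reads as a 1.2-fold lower number from compound 2 to compound 3 (0.07 log units; within the scatter), so at this position the phenethyloxy and pentyloxy chains cannot be told apart on this read-out. Against the methoxy group, the phenethyloxy chain gives a 7.8-fold lower number from compound 1 to compound 3 (0.89 log units; beyond the scatter), so both longer ethers shown stand beyond the scatter from methoxy, and the advantage seen with pentyloxy does not depend on a purely saturated chain end. No supporting measurement bears on the reason the two longer ethers read alike.

The compounds shown leave open how much the chain end can vary, as a fluorophenyl, a pyridine ring, an amine or a carboxylic acid at the end of the ether chain could each read differently from phenyl. They also leave open whether the phenyl needs to sit two bonds along the chain from the oxygen, a question that benzyloxy and a longer phenylpropyloxy chain would address.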